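The compounds below may be only part of what the source reports. "The series", "measured", "known", "first", "only" and "open" are said of these compounds alone.

Measured compounds:
- compound 1, `COc1cccc(/C=C/C(=O)/C=C/c2ccc(OCc3cn(CCCCOc4cc(=O)oc5ccccc45)nn3)c(OC)c2)c1`: 47%
- compound 2, `COc1cc(/C=C/C(=O)/C=C/c2ccccc2)ccc1OCc1cn(CCCCOc2cc(=O)oc3ccccc23)nn1`: 36%
- compound 3, `COc1ccccc1/C=C/C(=O)/C=C/c1ccc(OCc2cn(CCCCCOc3cc(=O)oc4ccccc34)nn2)c(OC)c1`: 37%

All three numbers come from a functional assay on THP-1 cells (Homo sapiens) for inhibition, read by sulforhodamine B assay, with a stated time of 48 h, tested at 50 uM; on this read-out lower numbers stand for less inhibition of growth and higher numbers for more inhibition of growth at the one concentration tested. Compound 1 and compound 2 share a core and differ in one place: hydrogen in place of methoxy on an aromatic carbon. That change gives a step of a number 11 percentage points lower from compound 1 to compound 2 (beyond the scatter). Compound 3 carries a core that differs from the core of compound 1; the difference between the two cores is not broken down here. The numbers for compound 2 and compound 3 lie within the scatter of each other, as do those for compound 3 and compound 1, so no order among them is claimed.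

Compound 4, `COc1cc(/C=C/C(=O)/C=C/c2ccccc2)ccc1OCc1cn(CCCCCOc2cc(=O)oc3ccccc23)nn1`, is not yet measured. It differs from compound 3 by hydrogen in place of methoxy on an aromatic carbon. This is the same kind of change as that from compound 1 to compound 2, but not the same: in the measured pair the methoxy that leaves sits meta to a large group, whereas in compound 3 it sits ortho to a large group. Going by the values given here, the expected step in this assay is therefore taken from the one measured pair, with added uncertainty for the different place: a step of a number 9 percentage points lower from compound 3 to compound 4 (within the scatter) is expected from compound 3 to compound 4, resting on the step of a number 11 percentage points lower from compound 1 to compound 2 (beyond the scatter). Among the compounds with values here, on this basis compound 4 is estimated at 28% in this assay, with a range from 14% to 42%, the pair compound 1 and compound 2 being the only guide here.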

Compound 4, percent growth inhibition at one concentration: 26%
Compound 4: the middle estimate sits 2 percentage points above what was measured; the measured number falls inside the stated range.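

Hydrogen in place of methoxy on an aromatic carbon gives a number 11 percentage points lower from compound 3 to compound 4 (beyond the scatter) in this assay, and the size of this step matches that of the step seen earlier on the other core: the same change on two cores in this assay, a number 11 percentage points lower (beyond the scatter) from compound 1 to compound 2 and a number 11 percentage points lower (beyond the scatter) from compound 3 to compound 4, 0 percentage points apart, within the scatter of two such steps

Within these two pairs, the change therefore carries from one core to the other with no gap in size, even though the methoxy that leaves sits ortho to a large group in compound 3 and at a different place in compound 1. This does not make a general rule: two pairs on two cores, read in one assay at a single concentration, cannot show that the step would hold on further cores or at other concentrations, and they give no reason for it.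

The compounds shown leave open whether another group at the same place, such as a hydroxy, a fluorine, an amine or a carboxylic acid, would give a number close to that of the methoxy or of the hydrogen. They also leave open what a shorter or longer linking chain would do on its own, with the aromatic substitution held fixed.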